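Biaryl bis-diazepane choline kinase series: removing the cyano group

The source may report more compounds than this note shows. Statements on the series, on what has been measured and on what is new or still open speak of the compounds shown alone.

Working notes on a symmetric biaryl series tested in an assay on isolated protein for inhibition of choline kinase alpha (Homo sapiens), with a stated time of 30 min; a lower number here means a stronger inhibitor, a higher number a weaker inhibitor. Compound 1 `CN1CCCN(Cc2ccc(-c3ccc(CN4CCCN(C)CC4)c(F)c3F)cc2)CC1` gives 233 nM in this assay. Among the measured compounds shown here, compound 2 `CN1CCCN(Cc2ccc(-c3ccc(CN4CCCN(C)CC4)cc3C#N)cc2)CC1` gives 66 nM in this assay and holds the lower of the two numbers so far; its gap to compound 1 lies beyond the usual scatter. Compound 3 `O=C(N1CCCCCC1)N1CCNCC1`, a small urea without the shared core, returns only a limit in this assay, > 300000 nM. One of the three values therefore sits at the limit of > 300000 nM in this assay, at which 1 of the 3 values shown sits.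

Compound 4 `CN1CCCN(Cc2ccc(-c3ccc(CN4CCCN(C)CC4)cc3)cc2)CC1` has not yet been measured in this assay. Against compound 2 the change is hydrogen in place of cyano on an aromatic carbon. For the measured compounds named here, no pair of measured compounds differs in exactly one place, so the expected size of this step cannot be read from a measured one; it rests on the numbers for compound 2 and compound 1 alone. With the cyano group gone, the number for compound 4 is expected to rise, that is, inhibition is expected to weaken, and the expected step of a 2.4-fold higher number from compound 2 to compound 4 (0.38 log units; beyond the scatter) is of a size likely beyond the scatter rather than a large loss. Compound 4 is expected to give about 160 nM in this assay, with a range of 55 nM to 480 nM.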

Compound 4, half-maximal inhibitory concentration: 457 nM
The estimate for compound 4 lay 2.9-fold (0.46 log units) below the measured number; the measured number falls inside the stated range.
By their numbers in this assay, from the lowest: compound 2; then compounds 1 and 4 (each within the scatter of the next). At a limit, above all of these: compound 3.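

In this assay, hydrogen in place of cyano on an aromatic carbon, ortho to a large group and meta to a (4-methyl-1,4-diazepan-1-yl)methyl group, gives a 6.9-fold higher number from compound 2 to compound 4 (0.84 log units; beyond the scatter). Among the compounds shown here, this is the first step that can be read at a single place, and it shows that this position is not indifferent to substitution: with the rest of the structure unchanged, the cyano group goes with clearly stronger inhibition than hydrogen. For the compounds shown here, nothing available bears on the reason for this step, as the only accompanying information concerns the assay limit reached by compound 3.

The compounds shown hold only cyano and hydrogen at this carbon, so it remains open whether a chlorine atom, a methyl group or a carboxamide would keep the number near that of compound 2 or whether the step is particular to the nitrile. Also open, from the compounds shown here alone, is whether a step of this size would carry over to a core bearing the two fluorine atoms of compound 1.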